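The compounds below may be only part of what the source reports. "The series", "measured", "known", "first", "only" and "open" are said of these compounds alone.

In a functional assay on HeLa cells (Homo sapiens) for antiproliferative activity, read by CCK-8 assay, with a stated time of 72 h (on this read-out higher numbers stand for weaker inhibition and lower numbers for stronger inhibition), compound 1 `COc1ccc(-c2cncnc2-c2cc(OC)c(OC)c(OC)c2)cc1` gives 1140 nM as its reading. Compound 2 `CCOc1ccc(-c2cncnc2-c2cc(OC)c(OC)c(OC)c2)cc1C(F)(F)F` gives 790 nM and lies within the scatter of compound 1, whereas compound 3 `COc1cc(-c2ncncc2-c2ccc(OCC(F)(F)F)cc2)cc(OC)c1OC` gives 10200 nM and stands clearly on the side of weaker inhibition. Compound 4 `COc1ccc(-c2cncnc2-c2cc(OC)c(OC)c(OC)c2)nc1` departs from compound 1 by one change (5-methoxypyridin-2-yl in place of 4-methoxyphenyl on an aromatic carbon) in which 5-methoxypyridin-2-yl sits in place of 4-methoxyphenyl on an aromatic carbon. Going by the values given here, no measured step makes this exchange. The nearest evidence is an 8.9-fold higher number from compound 1 to compound 3 (0.95 log units; beyond the scatter) with trifluoromethyl in place of hydrogen on a saturated chain carbon bound to an oxygen on an aromatic ring. Among the compounds with values here, that modest step, beyond the scatter, shows only that a change within this part of compound 1 can raise the number. A smaller rise is therefore expected, with real uncertainty over its size. An estimated 1.9-fold higher number from compound 1 to compound 4 (0.29 log units; within the scatter) is the expected move toward weaker inhibition. For compound 4 the expected value is 2200 nM (estimated range 600 nM to 8000 nM) in this assay once it is measured.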

Compound 4, half-maximal inhibitory concentration: 470 nM
Estimate against measurement, compound 4: 4.7-fold (0.67 log units) above; the measured number lies below the stated range.
By their numbers in this assay, from the lowest: compounds 4, 2 and 1 (each within the scatter of the next, the first and the last beyond it); then compound 3.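

In this assay, the step of a 2.4-fold lower number from compound 1 to compound 4 (0.38 log units; beyond the scatter) shows that the aryl group on this aromatic carbon, ortho to a large group and two atoms from the ring nitrogen, can itself be altered with a gain, as 5-methoxypyridin-2-yl in place of 4-methoxyphenyl lowers the number beyond the scatter. Going by these compounds alone, the only earlier single-place step, an 8.9-fold higher number from compound 1 to compound 3 (0.95 log units; beyond the scatter), changed the chain on the oxygen and went the other way, so this result is the first to show a lower number from a single-place change. Nothing measured here explains why swapping one ring carbon for nitrogen has this effect.

The compounds shown leave open whether an amine or a longer chain in place of the methoxy on the 5-methoxypyridin-2-yl group would keep the number this low. They also leave open whether a ring nitrogen elsewhere in that ring would do the same.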